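This account rests on a few compounds, and the source may have more. Where it says the series, first, only, none or still open, it means among the compounds named here.

Within the data shown here, compound 2, `O=C(Nc1cccc(/C=C/C(=O)c2nc3ccccc3[nH]2)c1)c1ccc(Br)cc1`, holds the higher of the two numbers measured so far in a functional assay on MCF7 cells (Homo sapiens) for antiproliferative activity, read by MTT assay, with a stated time of 48 h (a lower number here means a stronger inhibitor, a higher number a weaker inhibitor), where compound 2 gives 7000 nM. Among the measured compounds shown here, its nearest neighbour is compound 1, `O=C(/C=C/c1cccc(NC(=O)c2ccccc2Br)c1)c1nc2ccccc2[nH]1`, which in this assay gives 4520 nM; the single measured step, a 1.5-fold higher number from compound 1 to compound 2 (0.19 log units; within the scatter), stays within the scatter, so the two compounds cannot be told apart on these numbers. Compound 3, `Cc1ccc(C(=O)Nc2cccc(/C=C/C(=O)c3nc4ccccc4[nH]3)c2)cc1`, differs from compound 2 in one place: methyl in place of bromo on an aromatic carbon. For the measured compounds named here, no measured step bears directly on this exchange; the only step recorded moves the bromo around the ring without replacing it, and it produced no change beyond the scatter. With nothing pointing in either direction, compound 3 is expected to land close to compound 2 in this assay, with the expected step of a 1.2-fold lower number from compound 2 to compound 3 (0.07 log units; within the scatter) being one that would not stand out from repeat measurements. On that basis compound 3 is estimated at 6000 nM in this assay, with a plausible range from 2500 nM to 15000 nM.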

Compound 3, half-maximal inhibitory concentration: 9690 nM
Compound 3: middle estimate off by 1.6-fold (0.21 log units), on the low side; the measured number falls inside the stated range.
By their numbers in this assay, from the lowest: compounds 1, 2 and 3 (each within the scatter of the next, the first and the last beyond it).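

Among these compounds, the exchange of bromo for methyl on the aromatic carbon para to a large group gives the first direct reading of a replacement at this position: in this assay, a 1.4-fold higher number from compound 2 to compound 3 (0.14 log units; within the scatter), so one heavy atom replacing another here does not separate the two compounds. Among the compounds shown here, the 4-methylphenyl compound does, however, produce the first step in this small set to pass beyond the scatter, modest though it is, with a 2.1-fold higher number from compound 1 to compound 3 (0.33 log units; beyond the scatter), whereas the earlier step between the two bromophenyl compounds did not. Nothing measured alongside these numbers offers an explanation for either step.

The compounds shown leave open how much of the step from compound 1 belongs to the exchange of bromo for methyl and how much to the different place of the group on the ring. They also leave open whether an amine, a carboxylic acid or a longer chain at this same place, para to a large group, would move the number clearly beyond the scatter from compound 2.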